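Diaryl Urea Cytotoxicity: Swapping the Fluorophenyl for Dichlorophenyl

The compounds below may be only part of what the source reports. "The series", "measured", "known", "first", "only" and "open" are said of these compounds alone.

Compound 1: `Cc1cc(C)nc(Oc2ccc(NC(=O)Nc3ccc(Cl)cc3Cl)cc2)n1`, 38900 nM
Compound 2: `Cc1cc(C)nc(Sc2ccc(NC(=O)Nc3ccc(F)cc3)cc2)n1`, 34100 nM

Two diaryl ureas have been tested in a functional assay on CNE-2 cells (Homo sapiens) for cytotoxicity, read by MTT assay, with a stated time of 3 days; on this read-out higher numbers stand for weaker inhibition and lower numbers for stronger inhibition. Compound 1 gives 38900 nM and compound 2 gives 34100 nM in this assay. The two numbers sit within the usual scatter of each other, so neither compound stands apart from the other; compound 2 simply shares the weak-inhibition range that compound 1 occupies.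

Compound 3, `Cc1cc(C)nc(Sc2ccc(NC(=O)Nc3ccc(Cl)cc3Cl)cc2)n1`, is the next compound. It differs from compound 2 by 2,4-dichlorophenyl in place of 4-fluorophenyl on an amide-type nitrogen. Among the measured compounds shown here, no measured pair shows exactly this change on a shared core, so the direction of the step is open. Compound 1 already carries the 2,4-dichlorophenyl group and lands close to compound 2, which suggests compound 3 will stay in the same range. The expected step of a 1.1-fold lower number from compound 2 to compound 3 (0.06 log units; within the scatter) is therefore small, with no clear direction beyond the scatter. Compound 3 is estimated at 30000 nM, in a range from 12000 nM to 75000 nM.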

Compound 3, half-maximal inhibitory concentration: 23200 nM
For compound 3 the middle estimate is 1.3-fold (0.11 log units) above the measured one; measured number inside the range.
By their numbers in this assay, from the lowest: compounds 3, 2 and 1 (each within the scatter of the next).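

In this assay, among the compounds shown here, 2,4-dichlorophenyl in place of 4-fluorophenyl on an amide-type nitrogen gives a 1.5-fold lower number from compound 2 to compound 3 (0.17 log units; within the scatter), the first direct reading of this change with everything else in the molecule held the same. A second single change can now be read as well: (4,6-dimethylpyrimidin-2-yl)sulfanyl in place of (4,6-dimethylpyrimidin-2-yl)oxy on an aromatic carbon gives a 1.7-fold lower number from compound 1 to compound 3 (0.22 log units; within the scatter), so neither pair can be told apart in this small set. No measurement at hand offers an explanation for these results.

All three compounds carry only chlorine or fluorine on the phenyl ring at this nitrogen. Still open, on these data alone, is how a phenyl ring carrying an amine or a carboxylic acid would read there, and whether any such group would give a step beyond the scatter.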